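A few compounds are considered here, and "the series" means these few. Any claim that something is new, unique, unknown or untested is made for them only; others in the source may bear on it.

Measured so far:
- compound 1 `Cn1c(-c2ccc(NC(=O)CSc3nc4ccccc4o3)cc2)nc(-c2ccccc2)c1-c1ccccc1`, which in a functional assay on MCF7 cells (Homo sapiens) for cytotoxicity, read by MTT assay, with a stated time of 24 h, tested at 16 ug/mL (on this read-out higher numbers stand for a stronger effect at the one concentration tested and lower numbers for a weaker effect), gives 56%
- compound 2 `Cn1c(-c2ccc(NC(=O)CSc3nc4cc(Cl)ccc4o3)cc2)nc(-c2ccccc2)c1-c1ccccc1`, which in this assay gives 40%

Compound 2 stands lowest of the two, with the step of a number 16 percentage points lower from compound 1 to compound 2 (beyond the scatter). Compound 3 `Cc1nnc(SCC(=O)Nc2ccc(-c3nc(-c4ccccc4)c(-c4ccccc4)n3C)cc2)s1` differs from compound 2 by 5-methyl-1,3,4-thiadiazol-2-yl in place of 5-chloro-1,3-benzoxazol-2-yl on a sulfur. Among the compounds with values here, no measured step changes this part of the molecule, so the only guide is that compound 2 sits somewhat under compound 1 and the scatter is wide. The change is expected to shift the value little, giving a number 5 percentage points higher from compound 2 to compound 3 (within the scatter). Compound 3 is therefore estimated at 45%, within 25% to 65%.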

Compound 3, a percentage reported as activity, at one concentration (the size of the read-out at that concentration, not a potency): 74.9%
Compound 3: the middle estimate sits 29.9 percentage points below what was measured; measured number outside the range, above it.
By their numbers in this assay, from the lowest: compound 2; then compound 1; then compound 3.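

The group on the sulfur matters a great deal: 5-methyl-1,3,4-thiadiazol-2-yl in place of 5-chloro-1,3-benzoxazol-2-yl gives a number 34.9 percentage points higher from compound 2 to compound 3 (beyond the scatter) and in place of 1,3-benzoxazol-2-yl gives a number 18.9 percentage points higher from compound 1 to compound 3 (beyond the scatter) on the same shared core. A group with one five-membered aromatic ring therefore reads higher here than either group with two aromatic rings. Nothing available explains this rise. Still open, as far as these compounds go, is what the methyl on the thiadiazole contributes, and how a hydrogen or an amine in its place would read.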